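Replacing the allylamino group of compound 2

The compounds below may be only part of what the source reports. "The series", "measured", "known", "first", "only" and "open" are said of these compounds alone.

In a functional assay on the whole organism for positive allosteric modulation, with Mus musculus as the target (on this read-out lower numbers stand for an effect already at smaller amounts and higher numbers for an effect only at larger amounts of compound), compound 1 `CCC(=O)N(c1cccc(OC)c1)C1CCCC1N(C)C` gives 0.8 mg/kg and compound 2 `C=CCNC1CCCC1N(C(=O)CC)c1ccc(Cl)c(Cl)c1` gives 0.2 mg/kg as the lower of just two numbers. The gap between them lies beyond the usual scatter. These two compounds differ in more than one place, so the gap cannot be tied to any single change.

The next step leads to compound 3 `CCC(=O)N(c1ccc(Cl)c(Cl)c1)C1CCCC1N(C)CCCN(C)C` and puts (3-(dimethylamino)propyl)(methyl)amino in place of allylamino on a saturated ring carbon while the rest of compound 2 stays as it is. For the measured compounds named here, no measured pair isolates a change at this place, so any expectation here is weakly founded. A step of a 3.0-fold higher number from compound 2 to compound 3 (0.48 log units; beyond the scatter) toward a higher number is expected in this assay and a result within the scatter of compound 2 remains possible. The expected direction rests on compound 2 having 0.2 mg/kg as the lower value, with compound 1 at 0.8 mg/kg as the only other reference. For compound 3 the estimated dose is 0.6 mg/kg within an expected range from 0.1 mg/kg to 4 mg/kg for now.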

Compound 3, dose for half-maximal effect: 4 mg/kg
Beside the measured number, compound 3's estimate is 6.7-fold (0.82 log units) below it; low and high end bracket the measured number.
By their numbers in this assay, from the lowest: compound 2; then compound 1; then compound 3.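

In this assay, for the compounds shown here, the substituent on the saturated ring carbon turns out to matter strongly: (3-(dimethylamino)propyl)(methyl)amino in place of allylamino gives a large step (a 20-fold higher number from compound 2 to compound 3 (1.30 log units; beyond the scatter)), the first change that can be tied to a single place. The exchange alters several things at once, since the entering group has 8 heavy atoms against 4, a second nitrogen, no hydrogen-bond donor and no double bond, so the step belongs to the exchange as a whole and not to any one of these features. No measurement at hand explains the size of the step.

Going by these compounds, it remains open whether the step follows from the longer chain, the terminal dimethylamino group or the loss of the hydrogen-bond donor; methylamino or a 3-methoxypropyl chain at this place on the core of compound 2 would help to separate these. Compound 1 carries dimethylamino at this ring carbon but differs from compound 2 in more than one place, so it cannot settle the question.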